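Working notes: the methoxy-to-hydroxy step in the series

The compounds below may be only part of what the source reports. "The series", "measured", "known", "first", "only" and "open" are said of these compounds alone.

Among the measured compounds shown here, in an ADME assay on the whole organism for cytotoxicity, with Artemia salina as the target, with a stated time of 24 h (a lower number here means that less compound is needed, a higher number that more compound is needed for the effect), compound 2 `COc1ccc(/C=C/C(=O)c2ccccc2NC(=O)NS(=O)(=O)c2ccc(C)cc2)cc1` gives 28.1 ug/mL, the second highest of the three numbers measured so far. Its nearest neighbour is compound 1 `Cc1ccc(S(=O)(=O)NC(=O)Nc2ccccc2C(=O)/C=C/c2ccccc2)cc1`, which gives 25 ug/mL; the furthest is compound 3 `Cc1ccc(S(=O)(=O)NC(=O)Nc2ccccc2C(=O)/C=C/c2ccccc2O)cc1`, which gives 32.3 ug/mL. The step of a 1.1-fold higher number from compound 1 to compound 2 (0.05 log units; within the scatter) and the step of a 1.1-fold higher number from compound 2 to compound 3 (0.06 log units; within the scatter) are both within the scatter, so the three measured compounds cannot be separated on this read-out.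

Compound 4 `Cc1ccc(S(=O)(=O)NC(=O)Nc2ccccc2C(=O)/C=C/c2ccc(O)cc2)cc1` has not been measured in this assay. It differs from compound 2 by hydrogen in place of methyl on an oxygen on an aromatic ring. For the measured compounds named here, two measured steps bear on this change. The step of a 1.1-fold higher number from compound 1 to compound 2 (0.05 log units; within the scatter) shows that a methoxy group on the shared core of compound 1 changes nothing beyond the scatter, and the step of a 1.3-fold higher number from compound 1 to compound 3 (0.11 log units; within the scatter) shows the same for a hydroxy group, there as a 2-hydroxyphenyl rather than the 4-hydroxyphenyl of compound 4. Nothing in these steps suggests that exchanging methoxy for hydroxy would move the number. In this assay compound 4 is therefore expected near 30 ug/mL, in the range 15 ug/mL to 60 ug/mL. The expected step is a 1.1-fold higher number from compound 2 to compound 4 (0.03 log units; within the scatter), within the scatter.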

Compound 4, concentration for half-maximal effect: 24.3 ug/mL
Beside the measured number, compound 4's estimate is 1.2-fold (0.09 log units) above it; the measured number falls inside the stated range.
By their numbers in this assay, from the lowest: compounds 4, 1, 2 and 3 (each within the scatter of the next).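

In this assay, among the compounds shown here, the direct pair for hydrogen in place of methyl on an oxygen on an aromatic ring gives a 1.2-fold lower number from compound 2 to compound 4 (0.06 log units; within the scatter) and thus tests on one matched pair what the earlier compounds bore on only indirectly: 4-methoxyphenyl to 4-hydroxyphenyl is not resolved on this read-out. The other two new steps, a 1.3-fold lower number from compound 3 to compound 4 (0.12 log units; within the scatter) for 4-hydroxyphenyl in place of 2-hydroxyphenyl and a 1.0-fold lower number from compound 1 to compound 4 (0.01 log units; within the scatter) for hydroxy in place of hydrogen on an aromatic carbon, show that neither adding this hydroxy group nor the difference between these two hydroxyphenyl groups separates the compounds. No supporting data are available to explain this result.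

The compounds shown carry only hydrogen, methoxy or hydroxy on this phenyl ring, so it remains open whether an amine or a carboxylic acid there would give a step beyond the scatter. As far as these compounds go, it is equally open whether a longer chain on the oxygen, in place of methyl, would do so.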